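Amide aryl change from compound 2 to compound 3

This account rests on a few compounds, and the source may have more. Where it says the series, first, only, none or still open, it means among the compounds named here.

Among the compounds with values here, in a functional assay on A549 cells (Homo sapiens) for cytotoxicity, read by MTT assay, with a stated time of 72 h (a lower number here means a stronger inhibitor, a higher number a weaker inhibitor), compound 2 `Cc1ccc(F)cc1NC(=O)CN1CCN(c2nnc(Cc3ccncc3)c3ccccc23)CC1` gives 38900 nM, the higher of the two numbers so far. Compound 1 `O=C(CN1CCN(c2nnc(Cc3ccccc3)c3ccccc23)CC1)Nc1ccc(F)c(F)c1` gives 10100 nM, and the gap between them lies beyond the scatter. Compound 3 `O=C(CN1CCN(c2nnc(Cc3ccncc3)c3ccccc23)CC1)Nc1ccc(F)c(F)c1` is still unmeasured and departs from compound 2 in one place: 3,4-difluorophenyl in place of 5-fluoro-2-methylphenyl on an amide-type nitrogen, with 3,4-difluorophenyl in place of 5-fluoro-2-methylphenyl on an amide-type nitrogen. Within the data shown here, no measured pair isolates this change, since compound 1 and compound 2 differ in more than one place. Compound 1 does carry the same 3,4-difluorophenyl and gives 10100 nM, which points weakly toward a lower number. The expected move in this assay is therefore small and downward, roughly the size of the scatter: a 1.8-fold lower number from compound 2 to compound 3 (0.25 log units; within the scatter). For compound 3 the estimated value is 22000 nM, with an expected range of 9000 nM to 50000 nM.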

Compound 3, half-maximal inhibitory concentration: 3790 nM
Compound 3: the middle estimate sits 5.8-fold (0.76 log units) above what was measured; measured number outside the range, below it.
By their numbers in this assay, from the lowest: compound 3; then compound 1; then compound 2.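

In this assay, the amide aryl position proves sensitive: 3,4-difluorophenyl in place of 5-fluoro-2-methylphenyl on the amide-type nitrogen gives a 10-fold lower number from compound 2 to compound 3 (1.01 log units; beyond the scatter), a large step. The other place also responds, though with a modest step: pyridin-4-yl in place of phenyl on the saturated chain carbon gives a 2.7-fold lower number from compound 1 to compound 3 (0.43 log units; beyond the scatter), which makes compound 3 the strongest of the three, with both of its steps beyond the scatter. No supporting data explain either step.

The compounds shown do not separate loss of the methyl from gain of the second fluorine, and they give no pair testing the pyridin-4-yl change with 5-fluoro-2-methylphenyl on the amide. From the compounds shown here alone, how a phenyl carrying chlorine, an amine or a carboxylic acid would read at the amide position remains open.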